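The source may hold more compounds than are shown below. What is called first, only, known or untested is meant among the compounds shown, and "the series" means these compounds.

In a functional assay on P388D1 cells (Mus musculus) for antiproliferative activity, read by MTT assay (on this read-out lower numbers stand for stronger inhibition and higher numbers for weaker inhibition), compound 1 `CCOC(=O)N1CCCc2cc(S(=O)(=O)N3CC(c4ccccc4)NC3=O)ccc21` gives 1430 nM. Compound 2 `CC1(c2ccccc2)CN(S(=O)(=O)c2ccc3c(c2)CCCN3C(=O)C(F)(F)F)C(=O)N1` reports > 20000 nM, which is a limit and not a number, so it stands at the limit of > 20000 nM in this assay, at which 1 of the 2 values shown sits. Compound 3 `COc1ccc(NC(=O)N2CCCc3cc(S(=O)(=O)N4CC(C)(c5ccccc5)NC4=O)ccc32)cc1` carries (4-methoxyphenyl)amino in place of trifluoromethyl on a carbonyl carbon. Among the measured compounds shown here, no measured step covers this change, and the only numeric guide is compound 1 at 1430 nM. An expected step of an at least 13-fold lower number from compound 2 to compound 3 (1.12 log units; beyond the scatter) points toward stronger inhibition in this assay. For compound 3 the estimated value is 1500 nM, with an expected range of 200 nM to 12000 nM.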

Compound 3, half-maximal inhibitory concentration: 15900 nM
For compound 3 the middle estimate is 11-fold (1.03 log units) below the measured one; measured number outside the range, above it.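

In this assay compound 3 gives an actual number (15900 nM), so the series now has a readable value with (4-methoxyphenyl)amino on this carbonyl carbon. On these data alone, the change amounts to an at least 1.2-fold lower number from compound 2 to compound 3 (0.09 log units; that floor lies within the scatter) and so establishes no gain beyond the scatter, while its true size stays unknown. Compound 2 stands only at a limit: the limit of > 20000 nM in this assay, at which 1 of the 3 values shown sits.

Open, as far as these compounds go, is how plain phenylamino or a small methylamino would read on the same carbonyl carbon. Also open, from the compounds shown here alone, is what the methoxy group contributes to compound 3.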